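This account rests on a few compounds, and the source may have more. Where it says the series, first, only, none or still open, it means among the compounds named here.

Measured so far in a functional assay on THP-1 cells (Homo sapiens) for cytotoxicity, read by MTT assay, with a stated time of 24 h; on this read-out lower numbers stand for stronger inhibition and higher numbers for weaker inhibition:

Compound 1, `COc1cc(/C=C2\CN(C)C/C(=C\c3ccc(Cl)cc3Cl)C2=O)cc(OC)c1OC`, gives 5020 nM.
Compound 2, `COc1cc(/C=C2\CN(C)C/C(=C\c3ccc(Cl)c(Cl)c3)C2=O)cc(OC)c1OC`, gives 5330 nM.
Compound 3, `CN1C/C(=C\c2cccc([N+](=O)[O-])c2)C(=O)/C(=C/c2ccc(Cl)cc2Cl)C1`, gives 3560 nM.

Compounds 1 and 2 share one core; compound 3 carries a different core, and the difference between the two cores is not broken down here. Within the first pair, the change is 3,4-dichlorophenyl in place of 2,4-dichlorophenyl on a double-bonded chain carbon bound to a double-bonded ring carbon, and in this assay it made a 1.1-fold higher number from compound 1 to compound 2 (0.03 log units; within the scatter). The value of compound 3 in this assay sits within the usual scatter of both compound 1 and compound 2, so no ordering among the three is supported by these numbers.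

Compound 4, `CN1C/C(=C\c2cccc([N+](=O)[O-])c2)C(=O)/C(=C/c2ccc(Cl)c(Cl)c2)C1`, has not yet been measured. It differs from compound 3 by 3,4-dichlorophenyl in place of 2,4-dichlorophenyl on a double-bonded chain carbon bound to a double-bonded ring carbon, made at the same place as in the pair of compound 1 and compound 2; the change is therefore the same change, carried onto the core of compound 3. Going by the values given here, only one earlier instance of this change is available, and it stayed within the scatter. On that basis the step from compound 3 to compound 4 in this assay is expected to be a 1.1-fold higher number from compound 3 to compound 4 (0.04 log units; within the scatter), resting on the earlier step of a 1.1-fold higher number from compound 1 to compound 2 (0.03 log units; within the scatter) and on the measured value of compound 3, 3560 nM. The estimate for compound 4 in this assay is 3900 nM, expected to fall between 1900 nM and 8000 nM.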

Compound 4, half-maximal inhibitory concentration: 5020 nM
For compound 4 the middle estimate is 1.3-fold (0.11 log units) below the measured one, and the stated range covers the measured number.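

In this assay, 3,4-dichlorophenyl in place of 2,4-dichlorophenyl on a double-bonded chain carbon bound to a double-bonded ring carbon made a 1.4-fold higher number from compound 3 to compound 4 (0.15 log units; within the scatter). Set beside the earlier instance, the change reads alike on the two cores: the same change on two cores in this assay, a 1.1-fold higher number (0.03 log units; within the scatter) from compound 1 to compound 2 and a 1.4-fold higher number (0.15 log units; within the scatter) from compound 3 to compound 4, 1.3-fold (0.12 log units) apart, within the scatter of two such steps. This shows that, on these two cores, exchanging one dichlorophenyl for the other leaves the number within the usual scatter and that no dependence on the core can be seen; it does not show that either dichlorophenyl is better than the other, since neither step supports a direction, and two pairs say nothing about cores outside them.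

The compounds shown leave open whether a group of another kind at this place, such as an unsubstituted phenyl, an aminophenyl or a carboxyphenyl, would move the number beyond the scatter, since only the two dichlorophenyl groups are compared here. They also leave open whether the same exchange stays this quiet on a core carrying an amine or a longer chain in place of the groups seen so far.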